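This account rests on a few compounds, and the source may have more. Where it says the series, first, only, none or still open, it means among the compounds named here.

The shared core carries an amine bearing a benzyl group and, on the aromatic carbon between two ring nitrogen atoms, a variable group. Compound 1 `CCCCC[Se]c1nc(NCc2ccc(SC)cc2)c2ccccc2n1` carries a chain on selenium and a substituted benzyl group. In a functional assay on HT-29 cells (Homo sapiens) for cytotoxicity, read by MTT assay, with a stated time of 72 h (a lower number here means a stronger inhibitor of growth, a higher number a weaker inhibitor of growth), compound 1 reaches only > 100000 nM, a limit of the assay rather than a number. Compound 2 `Sc1nc(NCc2ccccc2)c2ccccc2n1` carries a sulfanyl group and the plain benzyl group. In this assay, among the compounds with values here, compound 2 gives 63500 nM, the only actual number among the values shown. The other value shown is the limit of > 100000 nM in this assay, at which 1 of the 2 values shown sits. Compound 3 `CCCCC[Se]c1nc(NCc2ccccc2)c2ccccc2n1` is not yet measured; it differs from compound 2 by a group of 6 heavy atoms (5 carbon, 1 selenium; no ring) in place of one sulfur atom, on an aromatic carbon. Within the data shown here, no single-change step between measured compounds exists to show the size of such a change. Since compound 1, which shares the chain on selenium, reached only > 100000 nM, compound 3 is expected to weaken by a 1.6-fold higher number from compound 2 to compound 3 (0.20 log units; within the scatter). The estimate for compound 3 is 100000 nM, within 30000 nM to 300000 nM.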

Compound 3, concentration for total growth inhibition: > 100000 nM
Compound 3: a limit, no number; the forecaster's own chance of this, stated with the estimate: 55%; the middle value sits exactly at the limit.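

On the aromatic carbon between two ring nitrogen atoms, putting the selenium-linked chain of 6 heavy atoms in place of the sulfanyl group gives, in this assay, an at least 1.5-fold higher number from compound 2 to compound 3 (0.19 log units; that floor lies within the scatter). Compound 3 gives > 100000 nM, which is a limit of the assay and not a number, so this change shows no stronger inhibition of growth, and any true loss cannot be sized. The step for hydrogen in place of methylsulfanyl on the benzyl group cannot be read, as both compounds stand at the same limit: the limit of > 100000 nM in this assay, at which 2 of the 3 values shown sit.

The compounds shown leave open whether the selenium atom or the chain sets compound 3 apart from compound 2, which a pentyl chain on sulfur or a shorter chain on selenium could separate. Also open, on these data alone, is whether an amine or a carboxylic acid on that carbon would give a lower number than compound 2.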